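The compounds below may be only part of what the source reports. "The series", "measured", "known", "first", "only" and "open" are said of these compounds alone.

In a functional assay on HCT-15 cells (Homo sapiens) for antiproliferative activity, read by CCK-8 assay, with a stated time of 72 h (on this read-out higher numbers stand for weaker inhibition and lower numbers for stronger inhibition), three compounds sharing one core have been measured, and they differ only in the group on the carbonyl carbon. Compound 1 (`COc1ccc(C2CC(c3ccccc3)=NN2C(=O)c2ccco2)cc1`) carries furan-2-yl and gives 3900 nM in this series. Compound 2 (`COc1ccc(C2CC(c3ccccc3)=NN2C(=O)c2nc3ccccc3s2)cc1`) carries 1,3-benzothiazol-2-yl and gives 1900 nM as the lowest number of the three. Compound 3 (`COc1ccc(C2CC(c3ccccc3)=NN2C(=O)c2ccncc2)cc1`) carries pyridin-4-yl and gives 10400 nM as the highest number. The measured steps are a 2.1-fold lower number from compound 1 to compound 2 (0.31 log units; beyond the scatter) and a 2.7-fold higher number from compound 1 to compound 3 (0.43 log units; beyond the scatter) and also a 5.5-fold higher number from compound 2 to compound 3 (0.74 log units; beyond the scatter) and all of them are modest.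

Compound 4 (`COc1ccc(C2CC(c3ccc(Cl)cc3)=NN2C(=O)c2nc3ccccc3s2)cc1`) keeps the 1,3-benzothiazol-2-yl group and differs from compound 2 by chloro in place of hydrogen on an aromatic carbon (chloro in place of hydrogen on an aromatic carbon, phenyl to 4-chlorophenyl). Among the measured compounds shown here, none of the measured steps touches this phenyl ring. For the measured compounds named here, all three change the group on the carbonyl carbon, so they offer no direct precedent for the chloro group and only suggest how wide the range might be. No step beyond the scatter is therefore expected, and the estimated step is a 1.4-fold lower number from compound 2 to compound 4 (0.13 log units; within the scatter) on this evidence. In this assay compound 4 is expected at 1400 nM with an estimated span from 500 nM to 4000 nM as its range.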

Compound 4, half-maximal inhibitory concentration: 4100 nM
Estimate against measurement, compound 4: 2.9-fold (0.47 log units) below; the whole stated range lies below it.
By their numbers in this assay, from the lowest: compound 2; then compounds 1 and 4 (each within the scatter of the next); then compound 3.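

In this assay, the phenyl ring of the shared core now proves responsive to substitution: chloro in place of hydrogen, on an aromatic carbon para to a large group, gives a 2.2-fold higher number from compound 2 to compound 4 (0.33 log units; beyond the scatter), a modest move towards weaker inhibition. Among the compounds shown here, the earlier compounds varied only the group on the carbonyl carbon, so this single step is the only information on this ring, and it was measured with the 1,3-benzothiazol-2-yl group held constant. Nothing available here explains why this change raises the number.

The compounds shown leave open whether this step reflects chloro specifically or would be seen with other groups at the same place on the ring, such as fluoro, methyl, an amine or a carboxylic acid. They also leave open whether phenyl to 4-chlorophenyl would give a step of similar size and direction with furan-2-yl or pyridin-4-yl on the carbonyl carbon, and whether moving the chloro elsewhere on the ring would change the outcome.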